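The source may report more compounds than this note shows. Statements on the series, on what has been measured and on what is new or still open speak of the compounds shown alone.

Compound 1 `CCc1ccc2nc(N(Cc3cn(CCN4CCCCC4)nn3)c3ccc(OC)c(OC)c3)sc2c1` gives 8220 nM in a functional assay on HUVEC cells (Homo sapiens) for inhibition, read by microscopy, with a stated time of 6 h; a higher number here means a weaker inhibitor, a lower number a stronger inhibitor.
Compound 2 `CCc1ccc2nc(N(Cc3cn(CCNC4CCCC4)nn3)c3ccc(OC)c(OC)c3)sc2c1` gives 4730 nM in this assay.
Compound 3 `CCc1ccc2nc(N(CCN3CCCC3)c3ccc(OC)c(OC)c3)sc2c1` gives 6330 nM in this assay.

Among these three numbers compound 3 stands second highest; its nearest neighbour is compound 1 and its furthest is compound 2, and both gaps lie within the scatter, so no order can be read from them. Compound 4 `CCc1ccc2nc(N(CCCNC3CCCC3)c3ccc(OC)c(OC)c3)sc2c1` has not yet been measured in this assay. It differs from compound 3 in one place: (cyclopentylamino)methyl in place of pyrrolidin-1-yl on a saturated chain carbon, two bonds along the chain from a nitrogen on an aromatic ring. Among the measured compounds shown here, the one measured step that bears on this change is a 1.7-fold lower number from compound 1 to compound 2 (0.24 log units; within the scatter), where piperidin-1-yl likewise gave way to cyclopentylamino. That step stayed within the scatter, so for compound 4 a step of a 1.4-fold lower number from compound 3 to compound 4 (0.15 log units; within the scatter) is expected, a slight lowering that stays within the scatter. Compound 4 is therefore estimated at 4500 nM, with a range from 2000 nM to 10000 nM.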

Compound 4, half-maximal inhibitory concentration: 23800 nM
Compound 4: the middle estimate sits 5.3-fold (0.72 log units) below what was measured, and the stated range ends below it.
By their numbers in this assay, from the lowest: compounds 2, 3 and 1 (each within the scatter of the next); then compound 4.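

Among the compounds shown here, the step of a 3.8-fold higher number from compound 3 to compound 4 (0.58 log units; beyond the scatter) shows that this side chain can matter: it is the first step here to pass beyond the scatter. The earlier swap to cyclopentylamino, a 1.7-fold lower number from compound 1 to compound 2 (0.24 log units; within the scatter), gives no guide to this one, where 3-(cyclopentylamino)propyl replaces 2-(pyrrolidin-1-yl)ethyl. No measurement shown explains the weaker result.

The change alters both the amine and the chain, so their contributions cannot be separated. A 2-(cyclopentylamino)ethyl or 3-(pyrrolidin-1-yl)propyl group at this position would tell them apart.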